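Acid to methylamide step, compound 2 to compound 4

The compounds below may be only part of what the source reports. "The series", "measured", "known", "first", "only" and "open" are said of these compounds alone.

Working notes on the series. Compound 2 `Cn1ccc2cc(-c3cnccc3/C=C/C(=O)O)ccc21` stands nowhere on a numbered scale: in a functional assay on KB cells (Homo sapiens) for inhibition, read by sulforhodamine B assay, with a stated time of 72 h (a lower number here means a stronger inhibitor of growth, a higher number a weaker inhibitor of growth), compound 2 returns only the limit > 10000 nM, not a number. Compound 1 `NC(=O)/C=C/c1ccncc1-c1ccc2ccccc2c1` also returns only the limit > 10000 nM in this assay. Compound 3 `O=C(CCc1ccncc1-c1ccc2ccccc2c1)N1CCOCC1` as well gives only the limit > 10000 nM in this assay. Among the compounds with values here, every value shown is thus (the limit of > 10000 nM in this assay, at which 3 of the 3 values shown sit), no step between measured compounds can be sized, and nothing in the measured set separates one compound from another.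

Compound 4 `CNC(=O)/C=C/c1ccncc1-c1ccc2c(ccn2C)c1` remains to be tested in this assay. It differs from compound 2 by methylamino in place of hydroxy on a carbonyl carbon. Since compound 1 and compound 3 share the limit of > 10000 nM in this assay, at which 3 of the 3 values shown sit, with compound 2, the measured set offers no instance of a change at the carbonyl carbon that brought growth inhibition into the numbered range. The step expected is a step that the limit leaves unreadable from compound 2 to compound 4, that is none beyond the scatter, with a further limit the likeliest outcome. Compound 4 is estimated at 15000 nM, with a range from 5000 nM to 50000 nM.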

Compound 4, concentration for 50% growth inhibition: 7080 nM
The estimate for compound 4 lay 2.1-fold (0.33 log units) above the measured number, and the stated range covers the measured number.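

In this assay, methylamino in place of hydroxy on a carbonyl carbon gives an at least 1.4-fold lower number from compound 2 to compound 4 (0.14 log units; that floor lies within the scatter) and makes compound 4 the only compound shown with a number rather than a limit. Compound 2 gives > 10000 nM here, which is a limit of the assay and not a number. Within the data shown here, the true size of the step therefore cannot be read, and its floor alone does not show a change beyond the scatter, while the single number stands against a set otherwise held at a limit: the limit of > 10000 nM in this assay, at which 3 of the 4 values shown sit.

On these data alone, whether this position tolerates further change on the carbonyl carbon remains open. A dimethylamino group, an ethylamino group or a longer chain on the amide nitrogen could show whether growth inhibition moves further from compound 4 in this assay.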